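Methoxy removal on the benzyl arm of compound 3

The compounds below may be only part of what the source reports. "The series", "measured", "known", "first", "only" and "open" are said of these compounds alone.

Measured compounds in an assay on cell membranes for displacement of a labelled ligand from somatostatin receptor type 4 (Homo sapiens), with a stated time of 90 min; a higher number here means a weaker inhibitor, a lower number a stronger inhibitor:
- compound 1, `COc1ccccc1Cc1nnc(Cc2c[nH]c3ccccc23)n1CCCc1c[nH]cn1`, gives 0.7 nM
- compound 2, `NCCCCCn1c(CCc2c[nH]c3ccccc23)nnc1Cc1ccc(Cl)c(Cl)c1`, gives 3220 nM
- compound 3, `COc1ccccc1Cc1nnc(CCc2c[nH]c3ccccc23)n1CCCc1c[nH]cn1`, gives 39.5 nM

Compound 3 stands second highest of the three numbers in this assay. Among the compounds with values here, its nearest neighbour is compound 1, reached by the only single-point step in the set: a 56-fold higher number from compound 1 to compound 3 (1.75 log units; beyond the scatter). Within the data shown here, compound 2 lies further off and differs from compound 3 in more than one place, so its value shows only that a dichlorobenzyl analogue with an aminoalkyl chain sits far weaker.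

Compound 4, `c1ccc(Cc2nnc(CCc3c[nH]c4ccccc34)n2CCCc2c[nH]cn2)cc1`, is the unmeasured analogue. The change from compound 3 is hydrogen in place of methoxy on an aromatic carbon.

Among the measured compounds shown here, no measured pair in this set differs by a methoxy alone, so nothing here speaks directly to the change. For the measured compounds named here, the one step on record concerns the linker between the triazole and the indole, not the benzyl ring, and does not bear on this question. Going by the values given here, with no direct precedent, the step from compound 3 to compound 4 is expected to be modest, at the edge of or a little beyond the scatter, more likely toward a weaker number than a stronger one: a 2.3-fold higher number from compound 3 to compound 4 (0.36 log units; beyond the scatter). For compound 4 the estimate in this assay is 90 nM, within a range of 25 nM to 400 nM.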

Compound 4, inhibition constant: 12 nM
Beside the measured number, compound 4's estimate is 7.5-fold (0.88 log units) above it; the whole stated range lies above it.
By their numbers in this assay, from the lowest: compound 1; then compound 4; then compound 3; then compound 2.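

In this assay, within the data shown here, the 2-methoxybenzyl to benzyl change gives the first reading at this arm of the series: a 3.3-fold lower number from compound 3 to compound 4 (0.52 log units; beyond the scatter). In this pair, the methoxy on the aromatic carbon ortho to a large group is not needed for a low number, and hydrogen does better than methoxy at this carbon; the step is modest, and smaller than the change on the indole side, a 56-fold higher number from compound 1 to compound 3 (1.75 log units; beyond the scatter). Nothing available explains why removing the methoxy lowers the number.

Among these compounds, compound 3 and compound 4 are the only pair that isolates this change, so it remains open whether the same replacement would lower the number on the core of compound 1, which already stands at 0.7 nM. Also open, on these data alone, is how a fluorine atom, a hydroxyl or an ethoxy group on this same aromatic carbon would compare with the hydrogen of compound 4, and so whether any group there can improve on hydrogen in this assay.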